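The source may hold more compounds than are shown below. What is called first, only, known or untested is meant among the compounds shown, and "the series" means these compounds.

In a functional assay on NUGC-3 cells (Homo sapiens) for cytotoxicity, read by sulforhodamine B assay, with a stated time of 72 h (on this read-out higher numbers stand for weaker inhibition of growth and lower numbers for stronger inhibition of growth), compound 1 `CC(=O)N1c2ccccc2CCC1C(=O)Nc1ccccc1O` gives 49700 nM and compound 2 `O=C(Nc1ccccc1O)C1CCc2ccccc2N1C(=O)c1ccc(Cl)cc1` gives 13400 nM. Compound 3 `O=C(Nc1ccc(C(F)(F)F)cc1)C1CCc2ccccc2N1` gives 18600 nM, within the scatter of compound 2. Compound 2 therefore stands with compound 3 at the low end of the three numbers. Within the data shown here, the only measured step, a 3.7-fold lower number from compound 1 to compound 2 (0.57 log units; beyond the scatter), puts 4-chlorophenyl in place of methyl on a carbonyl carbon, and compound 4 `O=C(Nc1ccccc1C(F)(F)F)C1CCc2ccccc2N1C(=O)c1ccc(Cl)cc1` keeps that 4-chlorophenyl. Compound 4 instead has trifluoromethyl in place of hydroxy on an aromatic carbon, ortho to a large group (trifluoromethyl in place of hydroxy on an aromatic carbon). Among the measured compounds shown here, no measured step makes this change, so the step above gives no direct guide to its size or direction. Compound 3 also carries trifluoromethyl, but it differs from compound 2 in more than one place and offers only loose support. No shift beyond the scatter is therefore expected in this assay. The expected change is a 1.1-fold higher number from compound 2 to compound 4 (0.05 log units; within the scatter). For compound 4 the estimated value is 15000 nM, with an expected range from 6000 nM to 38000 nM.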

Compound 4, concentration for 50% growth inhibition: 551 nM
Compound 4: the middle estimate sits 27-fold (1.43 log units) above what was measured; the measured number lies below the stated range.
By their numbers in this assay, from the lowest: compound 4; then compounds 2 and 3 (each within the scatter of the next); then compound 1.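

With the 4-chlorophenyl carbonyl kept in place, trifluoromethyl in place of hydroxy on an aromatic carbon, ortho to a large group, brings a 24-fold lower number from compound 2 to compound 4 (1.39 log units; beyond the scatter) in this assay. Among these compounds, this position, which no earlier step had touched, therefore moves the number further than the change on the carbonyl carbon, which gave a 3.7-fold lower number from compound 1 to compound 2 (0.57 log units; beyond the scatter). The data offer no measurement that could explain the size of this step.

The compounds shown leave open whether this step belongs to trifluoromethyl itself or would also appear with another group at this place, such as chlorine, a methoxy group or an amine. They also leave open whether the same exchange would bring a step of similar size with methyl rather than 4-chlorophenyl on the carbonyl carbon.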